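Sulfanyl analogue of compound 3 with fluoro for methoxy

The compounds below may be only part of what the source reports. "The series", "measured", "known", "first", "only" and "open" are said of these compounds alone.

Compound 1, `COc1cc(CNc2nc3cc(N)cc(N)c3nc2-c2ccccc2)cc(OC)c1OC`, gives 22400 nM in a functional assay on NCI-H226 cells (Homo sapiens) for inhibition, read by sulforhodamine B assay, with a stated time of 48 h; on this read-out lower numbers stand for stronger inhibition of growth and higher numbers for weaker inhibition of growth. Compound 2, `Nc1cc(N)c2nc(-c3ccccc3)c(NCc3ccc(F)cc3)nc2c1`, gives 47900 nM. Compound 3, `COc1ccc(Sc2nc3cc(N)cc(N)c3nc2-c2ccccc2)cc1`, stands only at a limit of this assay, < 100000 nM.

Compound 3 is thus placed by the limit of < 100000 nM in this assay, at which 1 of the 3 values shown sits, and not by a number, so a step that the limit leaves unreadable from compound 2 to compound 3 cannot be read. Compound 1 and compound 2 differ in more than one place; both give numbers inside the measured range.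

Compound 4, `Nc1cc(N)c2nc(-c3ccccc3)c(Sc3ccc(F)cc3)nc2c1`, differs from compound 3 by fluoro in place of methoxy on an aromatic carbon. Going by the values given here, no measured step touches this change, and the only step leading to compound 3 is unreadable. The expected step is a step that the limit leaves unreadable from compound 3 to compound 4, not readable against a limit. Compound 4 is therefore estimated at 60000 nM, range 15000 nM to 100000 nM, with a fair chance that only a limit is reported.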

Compound 4, concentration for total growth inhibition: 46800 nM
Compound 4: the middle estimate sits 1.3-fold (0.11 log units) above what was measured, within the range that was stated.
By their numbers in this assay, from the lowest: compound 1; then compounds 4 and 2 (each within the scatter of the next).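

In this assay, the change from (4-fluorobenzyl)amino to (4-fluorophenyl)sulfanyl is a 1.0-fold lower number from compound 2 to compound 4 (0.01 log units; within the scatter), so a sulfanyl group at this position can give a measured number, which compound 3 did not show. Both steps touching compound 3 remain unreadable, because that compound stands at a limit: the limit of < 100000 nM in this assay, at which 1 of the 4 values shown sits.

On these data alone, the size of the change from methoxy to fluoro therefore stays open. Also open, as far as these compounds go, is what an amine or a carboxylic acid would give in that place on the aromatic ring, or a longer chain in the link to the core.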